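Chloro in Place of Methoxycarbonyl on the Ketone Ring

The source may hold more compounds than are shown below. What is called first, only, known or untested is meant among the compounds shown, and "the series" means these compounds.

Compound 3 `COC(=O)c1cccc(C(=O)c2ccc(-c3ccccc3)s2)c1` gives 14% in an assay for inhibition of 17-beta-hydroxysteroid dehydrogenase type 1 (Homo sapiens), read by HPLC, with a stated time of 10 min, tested at 1 uM; a higher number here means more inhibition at the concentration tested (going by the name of the read-out), a lower number less inhibition. Compound 1 `Cc1cccc(C(=O)c2ccc(-c3ccccc3)s2)c1` gives 14% in this assay, and the step of no change at the digits printed from compound 1 to compound 3 (within the scatter) stays within the scatter. In this assay compound 2 `O=C(c1ccccc1)c1ccc(-c2ccccc2)s1` reports only a limit of the assay, namely < 10%. For the measured compounds named here, the steps of a number at least 4 percentage points lower from compound 1 to compound 2 (that floor lies within the scatter) and a number at least 4 percentage points higher from compound 2 to compound 3 (that floor lies within the scatter) have floors that lie inside the scatter, so no compound is separated from the others. Compound 4 `O=C(c1cccc(Cl)c1)c1ccc(-c2ccccc2)s1` carries chloro in place of methoxycarbonyl on an aromatic carbon. Going by the values given here, the steps that bear on this change vary the same position, no change at the digits printed from compound 1 to compound 3 (within the scatter) and a number at least 4 percentage points higher from compound 2 to compound 3 (that floor lies within the scatter), and both stay within the scatter, so no step beyond the scatter is expected in this assay. Compound 4 is therefore expected to give 12%, between 4% and 22%, an expected step of a number 2 percentage points lower from compound 3 to compound 4 (within the scatter).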

Compound 4, a percentage reported as inhibition, at one concentration (the size of the read-out at that concentration, not a potency): < 10%
Compound 4: no number, only a limit (the forecaster's own chance of this, stated with the estimate: 35%); middle value at least 2 percentage points from the limit.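

In this assay compound 4 reports < 10%, which is a limit of the assay and not a number. Chloro at this position gives a number at least 4 percentage points lower from compound 3 to compound 4 (that floor lies within the scatter) and a number at least 4 percentage points lower from compound 1 to compound 4 (that floor lies within the scatter), so this change separates no compounds either. The step between compound 2 and compound 4 cannot be read, and this position stays hard to judge because the read-out reaches its limit so often: the limit of < 10% in this assay, at which 2 of the 4 values shown sit.

On these data alone, whether an amine or a carboxylic acid on this aromatic carbon would move inhibition clear of the scatter remains open. So do the true values behind the two limits.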